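Compound 4: 4-methylphenyl in place of 3-bromophenyl

A few compounds are considered here, and "the series" means these few. Any claim that something is new, unique, unknown or untested is made for them only; others in the source may bear on it.

Compound 1 `OC[C@H]1O[C@@H](n2cnc3c(NCc4ccc(F)cc4)ncnc32)[C@H](O)[C@@H]1O` (1200 nM)
Compound 2 `OC[C@H]1O[C@@H](n2cnc3c(NCc4ccccc4Cl)ncnc32)[C@H](O)[C@@H]1O` (1600 nM)
Compound 3 `OC[C@H]1O[C@@H](n2cnc3c(NCc4cccc(Br)c4)ncnc32)[C@H](O)[C@@H]1O` (8000 nM)

In a functional assay on HL-60 cells (Homo sapiens) for antiproliferative activity, with a stated time of 72 h (on this read-out higher numbers stand for weaker inhibition and lower numbers for stronger inhibition), compound 3 has the highest number of the three (8000 nM), so it stands as the weakest inhibitor measured so far. Compound 4 `Cc1ccc(CNc2ncnc3c2ncn3[C@@H]2O[C@H](CO)[C@@H](O)[C@H]2O)cc1` is still to be measured. It differs from compound 3 at a single place (4-methylphenyl in place of 3-bromophenyl on a saturated chain carbon bound to a nitrogen on an aromatic ring). Among the measured compounds shown here, three measured steps bear on this change, and each exchanges the same aryl group. The two that end at 3-bromophenyl are modest, a 6.7-fold higher number from compound 1 to compound 3 (0.82 log units; beyond the scatter) and a 5.0-fold higher number from compound 2 to compound 3 (0.70 log units; beyond the scatter), and both lie beyond the scatter. The third, a 1.3-fold higher number from compound 1 to compound 2 (0.12 log units; within the scatter), stays within it. For the measured compounds named here, no compound with 4-methylphenyl has been measured, so the closest guide by name is compound 1 (1200 nM), which carries 4-fluorophenyl. A modest step towards a lower number is therefore expected, probably somewhat smaller than those two. The estimated step is a 2.9-fold lower number from compound 3 to compound 4 (0.46 log units; beyond the scatter) in this assay. For compound 4 the expected value is 2800 nM, with an estimated range from 900 nM to 8000 nM.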

Compound 4, half-maximal inhibitory concentration: > 166000 nM
Compound 4 was reported as a limit (the forecaster's own chance of this, stated with the estimate: 3%); middle value at least 59-fold (1.77 log units) away from the limit.
By their numbers in this assay, from the lowest: compounds 1 and 2 (each within the scatter of the next); then compound 3. At a limit, above all of these: compound 4.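

In this assay compound 4 is reported only as a limit and not as a number: the limit of > 166000 nM in this assay, at which 1 of the 4 values shown sits. Earlier aryl exchanges at this place, on a saturated chain carbon bound to a nitrogen on an aromatic ring, gave steps no greater than modest, whereas these are large (an at least 20-fold higher number from compound 3 to compound 4 (1.31 log units; beyond the scatter); an at least 100-fold higher number from compound 2 to compound 4 (2.01 log units; beyond the scatter)). The clearest case is methyl in place of fluoro on an aromatic carbon (an at least 130-fold higher number from compound 1 to compound 4 (2.14 log units; beyond the scatter)), which shows that this one exchange on the ring is enough to move a measurable value to a limit, although 3-bromophenyl and 4-methylphenyl have the same count of heavy atoms.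

Going by these compounds, how far compound 4 lies beyond its limit stays open. So does whether a methoxy, a chloro or an amine in place of that methyl would return a measurable value.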